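Swapping phenethyl for fluorophenoxy on the shared core

This account rests on a few compounds, and the source may have more. Where it says the series, first, only, none or still open, it means among the compounds named here.

Compound 1 `COc1ccc(F)cc1CNCCCNc1ccnc2cc(CCc3ccccc3)ccc12` and compound 2 `c1ccc(CCc2ccc3c(NCCCNCc4ccco4)ccnc3c2)cc1` have both been tested in a physicochemical assay for solubility, with a stated time of 18 h, at pH 7.4; on this read-out lower numbers stand for lower solubility and higher numbers for higher solubility. In this assay compound 1 gives 4200 nM. In this assay compound 2 gives 4200 nM. Among the compounds with values here, the single step between them, no change at the digits printed from compound 1 to compound 2 (within the scatter), swaps a group on a saturated chain carbon bound to an amine nitrogen, and the read-out stays level. On these numbers compound 1 thus stands level with compound 2.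

Compound 3 `COc1ccc(F)cc1CNCCCNc1ccnc2cc(Oc3ccc(F)cc3)ccc12` has not been measured. It differs from compound 1 at another place: 4-fluorophenoxy in place of phenethyl on an aromatic carbon. Within the data shown here, no measured step touches this aromatic carbon of the shared core, so the one step seen, which left the read-out unchanged, concerns a different position and offers no direct guide. With nothing pointing either way, the expected step of no change at the digits printed from compound 1 to compound 3 (within the scatter) is none beyond the scatter. Compound 3 is therefore estimated at 4200 nM in this assay, with a range from 1400 nM to 12000 nM to reflect the missing guidance.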

Compound 3, solubility: 14500 nM
Compound 3: the middle estimate sits 3.5-fold (0.54 log units) below what was measured; measured number above the stated range.
By their numbers in this assay, from the lowest: compounds 1 and 2 (each within the scatter of the next); then compound 3.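

In this assay the aromatic carbon of the shared core proves able to move the read-out: placing 4-fluorophenoxy there in place of phenethyl gives a 3.5-fold higher number from compound 1 to compound 3 (0.54 log units; beyond the scatter) and is the first step shown to go beyond the scatter, whereas the earlier step, on a saturated chain carbon bound to an amine nitrogen, gave no change at the digits printed from compound 1 to compound 2 (within the scatter). The step also comes without a change in the heavy-atom count, which stands at 8 for both groups, each with one six-membered aromatic ring of carbon only; the differences in the counts are 6 carbon, 1 oxygen and 1 fluorine against 8 carbon, and 1 hydrogen-bond acceptor against 0. No separate measurement bears on why the number moved.

The compounds shown do not separate the part played by the fluorine from that of the oxygen link, a question that plain phenoxy or a benzyloxy group at this carbon would address. Also open, from the compounds shown here alone, is whether 4-fluorophenoxy gives a similar step with furan-2-yl on the chain, as in compound 2.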